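The source may report more compounds than this note shows. Statements on the series, on what has been measured and on what is new or still open speak of the compounds shown alone.

Measured compounds in an ADME assay on BJ cells (Homo sapiens) for cytotoxicity, with a stated time of 72 h; a lower number here means that less compound is needed, a higher number that more compound is needed for the effect:

Compound 1 `Cc1cc(NC(=O)Nc2ccc(C(=O)O)cc2)c2ccccc2n1`: in this assay compound 1 gives > 25000 nM, a limit of the assay.
Compound 2 `CC(=O)c1ccc(NC(=O)Nc2cc(C)nc3ccccc23)cc1`: in this assay compound 2 gives 22000 nM.
Compound 3 `Cc1cc(NC(=O)Nc2ccc(SC(F)(F)F)cc2)c2ccccc2n1`: in this assay compound 3 gives > 25000 nM, again a limit of the assay.

Compound 3 thus stands at the limit, as does compound 1 (the limit of > 25000 nM in this assay, at which 2 of the 3 values shown sit); only compound 2 returned a number. Compound 4 `Cc1cc(NC(=O)Nc2ccc(C(C)(C)C)cc2)c2ccccc2n1` differs from compound 3 by tert-butyl in place of (trifluoromethyl)sulfanyl on an aromatic carbon. The measured steps that bear on this position are an at least 1.1-fold higher number from compound 2 to compound 3 (0.05 log units; that floor lies within the scatter) and a step that the two limits leave unreadable from compound 1 to compound 3; neither is readable beyond the scatter, and no measured change at this position has brought the number clearly below the limit. For compound 4 the expected step of a number no higher from compound 3 to compound 4 (the limit leaves the size open) is none beyond the scatter. Compound 4 is expected at 25000 nM, between 10000 nM and 60000 nM, most likely reported again only as a limit.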

Compound 4, half-maximal effective concentration: 20000 nM
Estimate against measurement, compound 4: 1.3-fold (0.10 log units) above; the range from low to high includes it.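

Tert-butyl in place of (trifluoromethyl)sulfanyl gives a measured number where compound 3 stood only at a limit, yet this reads as no more than an at least 1.2-fold lower number from compound 3 to compound 4 (0.09 log units; that floor lies within the scatter). Against the other two compounds, the change is also small: a 1.1-fold lower number from compound 2 to compound 4 (0.04 log units; within the scatter), and an at least 1.2-fold lower number from compound 1 to compound 4 (0.09 log units; that floor lies within the scatter). The series therefore stays close to the limit: the limit of > 25000 nM in this assay, at which 2 of the 4 values shown sit.

Still open, on these data alone, is whether an amine or a longer chain on this aromatic carbon would bring the number clearly below that limit. No change at this position shown so far has moved it beyond the scatter.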